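Cytotoxicity of deoxynucleoside analogues with varied side chains

The source may report more compounds than this note shows. Statements on the series, on what has been measured and on what is new or still open speak of the compounds shown alone.

Measured compounds:
Compound 1, `CCCCCc1cc(-c2cn([C@H]3C[C@H](OC(C)=O)[C@@H](COC(C)=O)O3)c(=O)[nH]c2=O)on1`: 3000 nM
Compound 2, `CCc1ccc(-c2cc(-c3cn([C@H]4C[C@H](OC(C)=O)[C@@H](COC(C)=O)O4)c(=O)[nH]c3=O)on2)cc1`: 3000 nM

Both measured compounds share the same core and differ only in the group on an aromatic carbon of the five-membered ring. In an ADME assay on HeLa cells (Homo sapiens) for cytotoxicity (on this read-out lower numbers stand for higher toxicity in this test and higher numbers for lower toxicity in this test), compound 1 gives 3000 nM, and compound 2 gives 3000 nM in this assay. Among the compounds with values here, the one measured step, no change at the digits printed from compound 1 to compound 2 (within the scatter), shows that exchanging pentyl for 4-ethylphenyl leaves the read-out unchanged within the scatter. Compound 1 therefore stands level with compound 2 on the numbers shown.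

Compound 3, `CC(=O)OC[C@H]1O[C@@H](n2cc(-c3cc(-c4ccc(C(C)C)cc4)no3)c(=O)[nH]c2=O)C[C@@H]1OC(C)=O`, is not yet measured. Its difference from compound 1 is 4-isopropylphenyl in place of pentyl on an aromatic carbon. Within the data shown here, the only step that bears on it is the one from compound 1 to compound 2, where a 4-ethylphenyl entered in place of the same pentyl and nothing moved beyond the scatter. A 4-isopropylphenyl is expected to behave alike, so the step of no change at the digits printed from compound 1 to compound 3 (within the scatter) is expected to show no change beyond the scatter. Compound 3 is thus estimated at 3000 nM in this assay, within 1200 nM to 8000 nM.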

Compound 3, half-maximal cytotoxic concentration: 3000 nM
For compound 3 middle estimate and measured number coincide at the digits printed; the measured number falls inside the stated range.
By their numbers in this assay, from the lowest: compounds 1, 2 and 3 (each within the scatter of the next).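

In this assay the aromatic carbon next to the ring nitrogen accepts a second aryl group with no visible effect: 4-isopropylphenyl in place of pentyl gives no change at the digits printed from compound 1 to compound 3 (within the scatter) and so repeats what the 4-ethylphenyl compound alone had shown. The new pair also isolates a smaller change within the aryl group, since methyl in place of hydrogen on the saturated chain carbon gives no change at the digits printed from compound 2 to compound 3 (within the scatter), and the read-out therefore separates neither the linear chain from the aryl groups nor the ethyl from the isopropyl end. No measured evidence on these compounds speaks to why the read-out stays flat across the three side chains.

Within the data shown here, the series so far holds only hydrocarbon side chains at this position, so it remains open whether an amine, a carboxylic acid or a much shorter chain such as methyl would move the read-out. Going by these compounds, it is also open whether the same flat result would hold with free hydroxyl groups in place of the two acetate esters on the shared core.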